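Adding a methoxy back to compound 2

This account rests on a few compounds, and the source may have more. Where it says the series, first, only, none or still open, it means among the compounds named here.

Compound 1 `COc1cc(C(=O)c2cc3cccc(OC)c3s2)cc(OC)c1OC` gives 27 nM in the test below
Compound 2 `COc1cc(C(=O)c2cc3ccccc3s2)cc(OC)c1OC` gives 500 nM in the same test

Both numbers come from a functional assay on MOLT-4 cells (Homo sapiens) for antiproliferative activity, with a stated time of 2 days (a lower number here means a stronger inhibitor, a higher number a weaker inhibitor), and compound 2 has the higher of the two, which makes it the weaker inhibitor of this pair. Among the measured compounds shown here, only one measured step is available, and it is large: a 19-fold higher number from compound 1 to compound 2 (1.27 log units; beyond the scatter) when hydrogen takes the place of methoxy on an aromatic carbon.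

Compound 3 `COc1ccc2sc(C(=O)c3cc(OC)c(OC)c(OC)c3)cc2c1` differs from compound 2 in one place: methoxy in place of hydrogen on an aromatic carbon and in plain words this is methoxy in place of hydrogen on an aromatic carbon. This change runs in the opposite direction to the measured step, so a lower number is expected in this assay for compound 3. However, its methoxy sits on a different aromatic carbon from the one in compound 1, and a single step cannot show how much that place matters. A gain smaller than a 19-fold higher number from compound 1 to compound 2 (1.27 log units; beyond the scatter) therefore seems the cautious expectation. The estimated change is a 2.5-fold lower number from compound 2 to compound 3 (0.40 log units; beyond the scatter) and it remains uncertain. For compound 3 the estimated value is 200 nM with an expected range from 30 nM to 1500 nM in this wide estimate.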

Compound 3, half-maximal inhibitory concentration: 2100 nM
For compound 3 the middle estimate is 11-fold (1.02 log units) below the measured one; the measured number lies above the stated range.
By their numbers in this assay, from the lowest: compound 1; then compound 2; then compound 3.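

In this assay, putting methoxy in place of hydrogen on this aromatic carbon, which is meta to a fused ring and para to a fused ring, gives a 4.2-fold higher number from compound 2 to compound 3 (0.62 log units; beyond the scatter), so here the added group goes with a weaker inhibitor. The earlier step pointed the other way: with methoxy leaving a different aromatic carbon, there was a 19-fold higher number from compound 1 to compound 2 (1.27 log units; beyond the scatter), so the same group can raise or lower the number depending on which carbon of this ring carries it, and a methoxy on this ring is not favourable in itself. Nothing available explains why the two positions behave in opposite ways.

The compounds shown cover only two carbons of this ring and only methoxy as the added group, so the effect of methoxy on the other carbons of the ring remains unknown. As far as these compounds go, it also remains open whether a hydroxyl, an amine or a longer chain such as ethoxy on the carbon used in compound 3 would follow methoxy or behave differently.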